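The source may hold more compounds than are shown below. What is called first, only, known or untested is meant among the compounds shown, and "the series" means these compounds.

Measured in an ADME assay on microsomes from liver (Rattus norvegicus) for metabolic stability; on this read-out lower numbers stand for a shorter-lived compound and higher numbers for a longer-lived compound:
Compound 1 `COc1cc(OCc2cccc(-c3ccc(C(F)(F)F)cn3)c2)c2cc(-c3cn4nc(OC)sc4n3)oc2c1`: > 2 h
Compound 2 `COc1cc(OCc2cccc(-c3cnc(OC)cn3)c2)c2cc(-c3cn4nc(OC)sc4n3)oc2c1`: 1.62 h

Compound 1 gives > 2 h, which is a limit of the assay and not a number. Going by the values given here, compound 2 gives 1.62 h, the only actual number so far, which makes it the reference point for what follows.

Compound 3 `COc1cc(OCc2cccc(OCc3ccccc3)c2)c2cc(-c3cn4nc(OC)sc4n3)oc2c1` keeps the core of compound 2 and exchanges one group: benzyloxy in place of 5-methoxypyrazin-2-yl on an aromatic carbon. Put simply, benzyloxy stands in place of 5-methoxypyrazin-2-yl on an aromatic carbon.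

Among the compounds with values here, one measured step bears on this change, as it exchanges a group at the same place: an at least 1.2-fold lower number from compound 1 to compound 2 (0.09 log units; that floor lies within the scatter). On these data alone, its true size is unknown because of the limit of > 2 h in this assay, at which 1 of the 2 values shown sits. Within the data shown here, it is a single step, and no compound measured so far carries benzyloxy, so it offers only a loose guide. On that basis, no change beyond the scatter is expected in this assay, with only a slight lean towards a shorter half-life.

The expected change is a 1.2-fold lower number from compound 2 to compound 3 (0.06 log units; within the scatter). For compound 3 the estimate is 1.4 h, with an expected range from 0.7 h to 2 h.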

Compound 3, half-life: 0.333 h
For compound 3 the middle estimate is 4.2-fold (0.62 log units) above the measured one; measured number outside the range, below it.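

In this assay, this place on the carbon-only aromatic ring proves sensitive to the group it carries, which the earlier step could not show: benzyloxy in place of 5-methoxypyrazin-2-yl gives a 4.9-fold lower number from compound 2 to compound 3 (0.69 log units; beyond the scatter). This happens with no change in the count of heavy atoms, since both groups have 8, so the size of the group by that count does not separate them. Benzyloxy in place of 5-(trifluoromethyl)pyridin-2-yl gives an at least 6.0-fold lower number from compound 1 to compound 3 (0.77 log units; beyond the scatter), and the true size of that step is unknown because of the limit: the limit of > 2 h in this assay, at which 1 of the 3 values shown sits.

The exchange changes two things at once, as the ring nitrogens leave and an oxygen-containing link to a carbon-only ring enters, and the compounds shown do not tell these two changes apart. A plain phenyl group would keep the direct attachment without the ring nitrogens, and a pyridylmethoxy group would keep the link with a ring nitrogen, so either could show which of the two changes goes with the shorter half-life.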